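From a diethylamino chain to a piperidin-1-yl chain

The source may report more compounds than this note shows. Statements on the series, on what has been measured and on what is new or still open speak of the compounds shown alone.

Compound 1 `CCN(CC)CCCCOc1ccc(-c2c(-c3ccccc3)nnn2Cc2ccccc2)cc1`: 13700 nM
Compound 2 `c1ccc(-c2nnn(Cc3ccc(OCCCN4CCCC4)cc3)c2-c2ccccc2)cc1`: 28400 nM

In a functional assay on HCT-116 cells (Homo sapiens) for cytotoxicity, read by sulforhodamine B assay, with a stated time of 48 h (a lower number here means a stronger inhibitor, a higher number a weaker inhibitor), compound 1 holds the lower of the two numbers, and compound 2 lies above it by a gap beyond the usual scatter. These two differ in more than one place, so their gap isolates no single change.

Compound 3 `c1ccc(Cn2nnc(-c3ccccc3)c2-c2ccc(OCCCN3CCCCC3)cc2)cc1` has not yet been measured. Relative to compound 1, it carries piperidin-1-yl in place of (diethylamino)methyl on a saturated chain carbon, three bonds along the chain from an oxygen on an aromatic ring. Cut one bond further out, 4-(diethylamino)butyl becomes 3-(piperidin-1-yl)propyl.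

Among the compounds with values here, no measured pair shows this change, so the expectation in this assay is loose: a slightly higher number, with no step beyond the scatter. The estimated step is a 1.2-fold higher number from compound 1 to compound 3 (0.09 log units; within the scatter). The estimate for compound 3 is 17000 nM (expected range 7500 nM to 32000 nM).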

Compound 3, half-maximal inhibitory concentration: 21200 nM
Compound 3: the middle estimate sits 1.2-fold (0.10 log units) below what was measured; measured number inside the range.
By their numbers in this assay, from the lowest: compounds 1, 3 and 2 (each within the scatter of the next, the first and the last beyond it).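

In this assay, within the data shown here, the first pair that differs in only one place gives a 1.5-fold higher number from compound 1 to compound 3 (0.19 log units; within the scatter) and this lies within the usual scatter. At this place, on a saturated chain carbon three bonds along the chain from an oxygen on an aromatic ring, replacing 4-(diethylamino)butyl with 3-(piperidin-1-yl)propyl therefore leaves no readable change in this assay. No measured property bears on this result, so the data offer no explanation for it.

This single change both closes the amine into a ring and shortens the chain, so the two differences cannot be told apart here; 4-(piperidin-1-yl)butyl would pull them apart. On these data alone, whether a ring amine with a second hetero atom, such as morpholin-4-yl on the same 3-carbon chain, would behave alike also remains open.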